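Amino to Methoxy on the Chalcone Ring

The compounds below may be only part of what the source reports. "The series", "measured", "known", "first", "only" and "open" are said of these compounds alone.

Compound 1 `COc1cc(-c2cc(/C=C/C(=O)c3ccc(N)cc3)[nH]n2)cc(OC)c1OC`: 6000 nM
Compound 2 `COc1ccc(-c2cc(/C=C/C(=O)c3ccc(N)cc3)[nH]n2)cc1OC`: 43200 nM

Of the compounds shown here, two have been tested in a functional assay on UO-31 cells (Homo sapiens) for inhibition, read by sulforhodamine B assay, with a stated time of 48 h; a higher number here means that more compound is tolerated, a lower number that less compound is tolerated. Compound 1 gives 6000 nM, the lowest number of the pair. For the measured compounds named here, compound 2 gives 43200 nM, and the single step between them, hydrogen in place of methoxy on an aromatic carbon, reads a 7.2-fold higher number from compound 1 to compound 2 (0.86 log units; beyond the scatter).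

Compound 3 `COc1ccc(C(=O)/C=C/c2cc(-c3cc(OC)c(OC)c(OC)c3)n[nH]2)cc1` differs from compound 1 at the other end of the shared core: methoxy in place of amino on an aromatic carbon. Cut one bond further out, the change reads 4-aminophenyl to 4-methoxyphenyl, sitting para to a large group.

Going by the values given here, the one measured step concerns the trimethoxyphenyl side of the core, not the ring that changes here, so it does not bear on this step. Among the compounds with values here, no measured pair shows what the exchange of amino for methoxy does. With no guide, the expected step in this assay is small and of uncertain direction, a 1.3-fold higher number from compound 1 to compound 3 (0.12 log units; within the scatter). Compound 3 is therefore estimated at 8000 nM, with a range from 2500 nM to 30000 nM.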

Compound 3, concentration lethal to 50% of the cells: 5590 nM
Compound 3: the middle estimate sits 1.4-fold (0.16 log units) above what was measured, and the stated range covers the measured number.
By their numbers in this assay, from the lowest: compounds 3 and 1 (each within the scatter of the next); then compound 2.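

In this assay, for the compounds shown here, this is the first measured change on the ring that carries the carbonyl, and the exchange of 4-aminophenyl for 4-methoxyphenyl gives a 1.1-fold lower number from compound 1 to compound 3 (0.03 log units; within the scatter). At this place, para to a large group, the two groups therefore cannot be told apart in this pair, even though the amino group brings a hydrogen-bond donor and the methoxy group brings none. The only step beyond the scatter so far remains the one at the other end of the shared core, a 7.2-fold higher number from compound 1 to compound 2 (0.86 log units; beyond the scatter), and no measurement shown accounts for the difference between the two ends.

What the compounds shown leave open is whether other groups at this place, such as a hydroxyl, a dimethylamino group or a carboxylic acid, would also stay within the scatter of compound 1. It also remains open whether the exchange of amino for methoxy would read the same on the core of compound 2, where the other end of the molecule has already been shown to matter.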